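The source may hold more compounds than are shown below. What is called first, only, known or untested is meant among the compounds shown, and "the series" means these compounds.

Values measured in a functional assay on MGC-803 cells (Homo sapiens) for antiproliferative activity, read by MTT assay, with a stated time of 72 h; a lower number here means a stronger inhibitor, a higher number a weaker inhibitor:

- Compound 1 `CCCSc1nc(N/N=C(\C)c2ccc(O)cc2)c2nnn(Cc3ccccc3)c2n1`: 16700 nM
- Compound 2 `CCCSc1nc(N/N=C(\C)c2ccc(OC)cc2)c2nnn(Cc3ccccc3)c2n1`: 44300 nM
- Compound 3 `C/C(=N\Nc1nc(SCc2ccccc2)nc2c1nnn2Cc1ccccc1)c1ccccc1O`: 850 nM

Compound 1 holds the middle place of the three, with a higher number than compound 3 and a lower number than compound 2. Compound 4 `CCCSc1nc(N/N=C/c2cccs2)c2nnn(Cc3ccccc3)c2n1` keeps the core of compound 1 but makes one change: a group of 7 heavy atoms (5 carbon, 1 nitrogen, 1 sulfur; one five-membered aromatic ring with 1 hetero atom) in place of a group of 10 heavy atoms (8 carbon, 1 nitrogen, 1 oxygen; one six-membered aromatic ring of carbon only), on a nitrogen on an aromatic ring. Among the measured compounds shown here, only one measured step bears on this, and it is modest: a 2.7-fold higher number from compound 1 to compound 2 (0.42 log units; beyond the scatter). For the measured compounds named here, that step alters a group on the six-membered ring that compound 4 loses, but no measured step replaces the ring itself. Compound 3 differs from compound 1 in more than one place, so it gives no direct guide. The expected step is a 1.2-fold higher number from compound 1 to compound 4 (0.08 log units; within the scatter), so no shift beyond the scatter is expected in this assay. For compound 4 the estimate is 20000 nM, with an expected range from 6000 nM to 60000 nM.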

Compound 4, half-maximal inhibitory concentration: > 64000 nM
Compound 4 was reported as a limit; the forecaster's own chance of this, stated with the estimate: 10%; at least 3.2-fold (0.50 log units) between middle value and limit.
By their numbers in this assay, from the lowest: compound 3; then compound 1; then compound 2. At a limit, above all of these: compound 4.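

Among the compounds shown here, until now, the only measured step altered a group on the six-membered aromatic ring; here the ring itself is replaced, and in this assay the result is an at least 3.8-fold higher number from compound 1 to compound 4 (0.58 log units; beyond the scatter). Compound 4 is reported as a limit, > 64000 nM, not as an exact number. So the five-membered aromatic ring with 1 hetero atom is no like-for-like stand-in for the six-membered ring here.

This one step also removes a hydrogen-bond donor and shrinks the group, so it cannot show which difference matters. On these data alone, whether an amine or a carboxylic acid on the six-membered ring would hold the number near that of compound 1 remains open.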